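From chlorophenyl to hydroxyphenyl at the assay's limit

A few compounds are considered here, and "the series" means these few. Any claim that something is new, unique, unknown or untested is made for them only; others in the source may bear on it.

In an ADME assay on HEK293 cells (Homo sapiens) for cytotoxicity, read by resazurin assay, with a stated time of 48 h (on this read-out lower numbers stand for higher toxicity in this test and higher numbers for lower toxicity in this test), compound 1 (`O=S(=O)(Nc1ccc(-c2nc3ccccc3o2)cc1)c1ccccc1Cl`) gives > 100000 nM as its result, and that is a limit, not a number. In this assay compound 3 (`O=S(=O)(Nc1ccc2oc(-c3ccccc3)nc2c1)c1cccc(O)c1`) likewise gives > 100000 nM as a limit. Compound 2 (`COc1ccccc1S(=O)(=O)Nc1ccc2oc(-c3ccccc3)nc2c1`) alone yields a true number, at 41000 nM on the same scale. Compound 1 thus stands at the limit of > 100000 nM in this assay, at which 2 of the 3 values shown sit, and has no exact number to start from.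

Compound 4 (`O=S(=O)(Nc1ccc(-c2nc3ccccc3o2)cc1)c1ccc(O)cc1`) has not yet been measured. Its difference from compound 1 is 4-hydroxyphenyl in place of 2-chlorophenyl on a sulfonyl sulfur and amounts to 4-hydroxyphenyl in place of 2-chlorophenyl on a sulfonyl sulfur.

Among the measured compounds shown here, only one measured step offers a guide, and it comes from a different core. The step of an at least 2.4-fold higher number from compound 2 to compound 3 (0.38 log units; beyond the scatter) puts 3-hydroxyphenyl in place of 2-methoxyphenyl on a sulfonyl sulfur, and it is modest but beyond the scatter. It moves towards higher numbers and ends at the limit, so this single case gives no sign that a hydroxyphenyl group lowers the number. The expected size of the step is a number no higher from compound 1 to compound 4 (the limit leaves the size open) and no change beyond the scatter is foreseen. Compound 4 is estimated at 100000 nM with a range from 45000 nM to 200000 nM and may well return only a limit.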

Compound 4, half-maximal cytotoxic concentration: > 100000 nM
Compound 4 gave a limit, no number; the forecaster's own chance of this, stated with the estimate: 75%; the middle value lies on the limit itself.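

In this assay compound 4 gives > 100000 nM, which is a limit and not a number. Among the compounds shown here, compound 1 gives a limit too, so no step from compound 1 to compound 4 can be read, and both compounds stand at the same point: the limit of > 100000 nM in this assay, at which 3 of the 4 values shown sit. The compounds shown leave open whether 4-hydroxyphenyl or 2-chlorophenyl on a sulfonyl sulfur gives the higher number.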